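The source may report more compounds than this note shows. Statements on the series, on what has been measured and on what is new or still open speak of the compounds shown alone.

In a functional assay on KB cells (Homo sapiens) for cytotoxicity (on this read-out lower numbers stand for stronger inhibition and higher numbers for weaker inhibition), the set holds three measured compounds on a shared core. Compound 1 `Cn1cc(C#N)c2c(N)ncnc21` gives only a limit of the assay, > 100000 nM. Compound 2 `N#Cc1cn(COCc2ccccc2)c2ncnc(N)c12`, with a benzyloxymethyl group on the ring nitrogen, likewise gives only a limit, > 100000 nM. Within the data shown here, compound 3 `CCOCn1cc(C(=N)S)c2c(N)ncnc21`, which carries an ethoxymethyl group, is the one compound for which this assay returns a number, 68000 nM; it therefore stands alone among the values shown, and the limit of > 100000 nM in this assay, at which 2 of the 3 values shown sit, marks where the other two sit.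

Compound 4 `CCOCn1cc(C#N)c2c(N)ncnc21` keeps the ethoxymethyl group of compound 3 but differs in a single place: a group of 2 heavy atoms (1 carbon, 1 nitrogen; no ring) in place of a group of 3 heavy atoms (1 carbon, 1 nitrogen, 1 sulfur; no ring), on an aromatic carbon. With this change compound 4 comes to resemble compound 1 and compound 2, which both carry cyano and both give only limits. On that basis the step from compound 3 to compound 4 is expected to be a loss of potency beyond the scatter, a 2.2-fold higher number from compound 3 to compound 4 (0.34 log units; beyond the scatter), and compound 4 is expected to lie at 150000 nM, in the range 50000 nM to 500000 nM, most probably as a limit rather than a number.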

Compound 4, half-maximal inhibitory concentration: > 100000 nM
Compound 4 gave a limit, no number; the forecaster's own chance of this, stated with the estimate: 75%; the middle value does not contradict the limit.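

Among these compounds, with the ethoxymethyl group held constant, this pair gives the first direct comparison at this aromatic carbon in this assay, with cyano entering in place of the sulfur-bearing group: an at least 1.4-fold higher number from compound 3 to compound 4 (0.16 log units; that floor lies within the scatter). Among the compounds shown here, the direction fits compound 3 holding the only number in the set, but the floor alone does not establish a real loss of potency. Compound 1, compound 2 and compound 4 all carry cyano, and changing the group on the ring nitrogen among them moves no reading off the limit: the limit of > 100000 nM in this assay, at which 3 of the 4 values shown sit.

The steps from compound 1 and from compound 2 to compound 4 cannot be read, so any effect of the ring-nitrogen group remains unresolved. Going by these compounds, it also remains open how far compound 4 lies from compound 3, and whether a carboxamide or a carboxylic acid on this aromatic carbon would return a number.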